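Swapping the halogenated ring for a methoxymethyl-bearing ring

This account rests on a few compounds, and the source may have more. Where it says the series, first, only, none or still open, it means among the compounds named here.

The three measured compounds and their values:
Compound 1, `CCOc1ccccc1-c1ccc(-c2nc3cnccc3c(N[C@H](CC)C(N)=O)c2C#N)cc1`: 3
Compound 2, `CC[C@@H](Nc1c(C#N)c(-c2ccc(-c3ccccc3NC)cc2)nc2cnccc12)C(N)=O`: 2.5
Compound 3, `CC[C@@H](Nc1c(C#N)c(-c2ccc(-c3cccc(Cl)c3F)cc2)nc2cnccc12)C(N)=O`: 3.1

All three share one core and differ only in the outer aromatic ring. In a physicochemical assay for lipophilicity, read by HPLC, at pH 7.5 (on this read-out lower numbers stand for lower lipophilicity and higher numbers for higher lipophilicity), compound 3 gives the highest of the three numbers; the gap to compound 1 is within the scatter, a number 0.10 log units higher from compound 1 to compound 3 (within the scatter), while the gap to compound 2 is clearer, a number 0.60 log units higher from compound 2 to compound 3 (beyond the scatter).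

Compound 4, `CC[C@@H](Nc1c(C#N)c(-c2ccc(-c3ccccc3COC)cc2)nc2cnccc12)C(N)=O`, is not yet measured. It differs from compound 3 in one place: 2-(methoxymethyl)phenyl in place of 3-chloro-2-fluorophenyl on an aromatic carbon.

Among the compounds with values here, two measured steps bear on this. The step of a number 0.10 log units higher from compound 1 to compound 3 (within the scatter) shows that exchanging a 2-ethoxyphenyl for the 3-chloro-2-fluorophenyl hardly moved the number, and a number 0.60 log units higher from compound 2 to compound 3 (beyond the scatter) shows that a 2-(methylamino)phenyl sat clearly lower. An oxygen-containing ring of the new kind is expected to land between those two cases, so a small drop is expected, a number 0.40 log units lower from compound 3 to compound 4 (beyond the scatter), near the edge of the scatter. Compound 4 is therefore estimated at 2.7, expected between 2.3 and 3.1.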

Compound 4, distribution coefficient: 2.6
Estimate against measurement, compound 4: 0.10 log units above; low and high end bracket the measured number.
By their numbers in this assay, from the lowest: compounds 2 and 4 (each within the scatter of the next); then compounds 1 and 3 (each within the scatter of the next).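

In this assay, 2-(methoxymethyl)phenyl at this position does not match 3-chloro-2-fluorophenyl (a number 0.50 log units lower from compound 3 to compound 4 (beyond the scatter)). Methoxymethyl instead reads level with methylamino (a number 0.10 log units higher from compound 2 to compound 4 (within the scatter)) but apart from ethoxy (a number 0.40 log units lower from compound 1 to compound 4 (beyond the scatter)), so carrying an oxygen does not by itself fix the number at this position among these compounds. No available evidence explains these differences. The compounds shown leave open how the number would respond to a carboxylic acid, a primary amine or a longer ether chain on this outer ring.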